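A few compounds are considered here, and "the series" means these few. Any claim that something is new, unique, unknown or untested is made for them only; others in the source may bear on it.

The measured compounds:
Compound 1, `Nc1ccc(-c2cnc(N)c(-c3ccc(N)nc3)n2)cn1`, in an ADME assay on microsomes from liver (Homo sapiens) for metabolic stability, read by LC-MS, using NADPH, with a stated time of 30 min, tested at 0.1 uM, in the presence of a further agent that is not named here (a higher number here means that more of the compound is left, a lower number that less of the compound is left), gives > 90%, which is a limit of the assay and not a number.
Compound 2, `NC(=O)c1ccc(-c2cnc(N)c(-c3ccc(C(F)(F)F)cc3)n2)cc1`, gives > 90%, also a limit.
Compound 3, `Nc1ncc(-c2ccc(C(=O)N3CCC(O)C3)cc2)nc1-c1ccc(C(F)(F)F)cc1`, gives > 90%, again a limit.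

Compound 2 therefore stands only at a limit in this assay, and the other two values shown are limits as well (the limit of > 90% in this assay, at which 3 of the 3 values shown sit); none of the three can be ranked against the others.

Compound 4, `Nc1ncc(-c2ccc(C(=O)N3CC[C@@H](O)C3)cc2)nc1-c1ccc(C(F)(F)F)cc1`, differs from compound 2 in one place: 3-hydroxypyrrolidin-1-yl in place of amino on a carbonyl carbon. Going by the values given here, the only measured step of the same kind is a step that the two limits leave unreadable from compound 2 to compound 3, a step whose size cannot be read, since both of its ends sit at the limit. Compound 3 differs from compound 4 only in that compound 4 carries a defined stereocentre on the 3-hydroxypyrrolidin-1-yl group. So no step of readable size bears on the change, and the only guidance is that compound 3, which shares the same group, stays at the limit. Compound 4 is expected to do the same, with an estimated 95%, ranging from 85% to 100%. The estimated step that the limit leaves unreadable from compound 2 to compound 4 is expected to be none beyond the scatter.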

Compound 4, percent of the compound remaining: > 90%
Compound 4 was reported as a limit; the forecaster's own chance of this, stated with the estimate: 85%; the middle value is on the limit's open side.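

Compound 4 gives > 90% in this assay and this is a limit, not a number. No new step can be read from compound 2 or compound 3 to compound 4, since all these values sit at one limit: the limit of > 90% in this assay, at which 4 of the 4 values shown sit.

As far as these compounds go, what stays open is how far each compound lies past that limit, and so whether the 3-hydroxypyrrolidin-1-yl group or its defined configuration makes any difference in this assay at all.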